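Adding a Second Chlorine to the Benzyl Group

The source may hold more compounds than are shown below. What is called first, only, known or untested is meant among the compounds shown, and "the series" means these compounds.

Compound 2 `Cc1ccc(-c2nn(-c3ccccc3)cc2C(=O)NOCc2ccccc2Cl)cc1` stands lowest of the two numbers measured in a functional assay on A549 cells (Homo sapiens) for antiproliferative activity, read by MTT assay, with a stated time of 48 h, in the presence of a further agent that is not named here; on this read-out lower numbers stand for stronger inhibition of growth and higher numbers for weaker inhibition of growth: compound 2 gives 380 nM. Compound 1 `O=C(NOCc1ccc(Cl)cc1Cl)c1cn(-c2ccccc2)nc1-c1ccccc1` differs from compound 2 in two places. In this assay compound 1 gives 7350 nM, a gap beyond the scatter. Compound 3 `Cc1ccc(-c2nn(-c3ccccc3)cc2C(=O)NOCc2ccc(Cl)cc2Cl)cc1` is not yet measured and differs from compound 2 by chloro in place of hydrogen on an aromatic carbon. No single-change comparison of this kind exists among the measured compounds, so the direction is uncertain. Compound 1, with 7350 nM, carries the same dichloro group but also another difference. A modest step toward weaker inhibition is expected, a 2.4-fold higher number from compound 2 to compound 3 (0.37 log units; beyond the scatter). Compound 3 is estimated at 900 nM, within 250 nM to 3500 nM.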

Compound 3, concentration for 50% growth inhibition: 1080 nM
Compound 3: the middle estimate sits 1.2-fold (0.08 log units) below what was measured; the measured number falls inside the stated range.
By their numbers in this assay, from the lowest: compound 2; then compound 3; then compound 1.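

In this assay chloro in place of hydrogen, para to a large group on the 2-chlorobenzyl ring, gives a 2.8-fold higher number from compound 2 to compound 3 (0.45 log units; beyond the scatter) and so weakens growth inhibition. For the compounds shown here, compound 3 also isolates the methyl group on the aromatic carbon for the first time: methyl in place of hydrogen gives a 6.8-fold lower number from compound 1 to compound 3 (0.83 log units; beyond the scatter) and so strengthens growth inhibition in the 2,4-dichlorobenzyl series. No measurement shown explains either step.

From the compounds shown here alone, whether a fluoro or methoxy group at the chloro position would behave the same way remains open. So does the effect of removing the 2-chloro group.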